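The compounds below may be only part of what the source reports. "The series", "measured", "known", "first", "only" and "open" are said of these compounds alone.

Working notes on the urea series, all three measured members sharing one core. Compound 1 `CNc1cc(Oc2ccc(NC(=O)Nc3ccccc3)cc2)ncn1` carries methylamino on the core and an unsubstituted phenyl on the urea; in an assay on isolated protein for inhibition of serine/threonine-protein kinase TNNI3K (Homo sapiens) (a higher number here means a weaker inhibitor, a lower number a stronger inhibitor), compound 1 gives 6300 nM. Compound 2 `CC(C)CNc1cc(Oc2ccc(NC(=O)Nc3cccc(C(F)(F)F)c3)cc2)ncn1` carries isobutylamino on the core and trifluoromethyl on the urea phenyl; in this assay compound 2 gives 50 nM. Compound 3 `CNc1cc(Oc2ccc(NC(=O)Nc3cccc(C(F)(F)F)c3)cc2Cl)ncn1` carries methylamino with trifluoromethyl on the urea phenyl and chloro on the central phenyl; in this assay compound 3 gives 50 nM. Compound 2 stands level with compound 3 at the digits shown, the two together giving the lowest numbers of the three, and the gap from compound 1 to compound 2 is beyond the scatter. Going by the values given here, no single-point comparison exists among the measured compounds, so no step is quantified.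

Compound 4 `Cc1cc(Oc2ccc(NC(=O)Nc3cccc(C(F)(F)F)c3)cc2)ncn1` is the next member. Its difference from compound 2: methyl in place of isobutylamino on an aromatic carbon. With this change one hydrogen-bond donor and one hydrogen-bond acceptor are removed from the core, and nothing among compounds 1 to 3 tests that change. The expectation for this assay is a step from compound 2 to compound 4 of an 8.0-fold higher number from compound 2 to compound 4 (0.90 log units; beyond the scatter), toward a weaker inhibitor, beyond the scatter. Compound 4 is estimated at 400 nM, with a range from 100 nM to 2000 nM.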

Compound 4, half-maximal inhibitory concentration: 160 nM
Beside the measured number, compound 4's estimate is 2.5-fold (0.40 log units) above it, and the stated range covers the measured number.
By their numbers in this assay, from the lowest: compounds 2 and 3 (each within the scatter of the next); then compound 4; then compound 1.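

In this assay, methyl in place of isobutylamino on this aromatic carbon gives a 3.2-fold higher number from compound 2 to compound 4 (0.51 log units; beyond the scatter), a modest step beyond the scatter, so this position keeps measurable inhibition without any amino nitrogen. The step is small beside the full span of the series, and compound 4 still lies well below compound 1, although those two differ in more than one place and give no clean comparison. The change removes the nitrogen, with its hydrogen-bond donor and acceptor, together with the chain, and no measurement here explains the higher number.

Going by these compounds alone, the single step cannot separate the loss of the nitrogen from the shortening of the chain. A plain amine on this carbon, or a longer carbon chain attached directly without nitrogen, would bear on that question.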